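The compounds below may be only part of what the source reports. "The series", "measured", "known", "first", "only" and "open" are said of these compounds alone.

In a functional assay on Caco-2 cells (Homo sapiens), read by MTT assay, with a stated time of 48 h (on this read-out lower numbers stand for stronger inhibition and higher numbers for weaker inhibition), three compounds that share one core have been measured. Compound 1 `CCn1c(C(=O)NCC(OC)OC)ccc1C(CC)(CC)c1ccc(OCC(O)C(C)(C)C)c(C)c1` is reported only as a limit, > 50000 nM. Compound 3 `C=CCN(C)C(=O)c1ccc(C(CC)(CC)c2ccc(OCC(O)C(C)(C)C)c(C)c2)n1CC` is also reported only as a limit, > 50000 nM, so it has no number of its own. Compound 2 `CCn1c(C(=O)NCCN)ccc1C(CC)(CC)c1ccc(OCC(O)C(C)(C)C)c(C)c1` alone gives a number, 1000 nM.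

The next change leads to compound 4 `CC[C@@H](C)[C@H](NC(=O)c1ccc(C(CC)(CC)c2ccc(OCC(O)C(C)(C)C)c(C)c2)n1CC)C(=O)O`: (1-carboxy-2-methylbutyl)amino in place of allyl(methyl)amino on a carbonyl carbon. In words, (1-carboxy-2-methylbutyl)amino stands in place of allyl(methyl)amino on a carbonyl carbon.

Going by the values given here, two measured steps bear on this change, and both are large: an at least 50-fold lower number from compound 1 to compound 2 (1.69 log units; beyond the scatter), and an at least 50-fold higher number from compound 2 to compound 3 (1.69 log units; beyond the scatter). Both run through compound 2, and compound 4 does not carry its (2-aminoethyl)amino group. A gain of that size is therefore not expected here, and compound 4 may well be reported only as a limit too. The expected step, small and toward stronger inhibition if it can be read at all, is an at least 1.6-fold lower number from compound 3 to compound 4 (0.22 log units; that floor lies within the scatter). The estimated value for compound 4 is 30000 nM, with an expected range of 6000 nM to 100000 nM.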

Compound 4, half-maximal inhibitory concentration: 3400 nM
Estimate against measurement, compound 4: 8.8-fold (0.95 log units) above; measured number outside the range, below it.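

In this assay, going by these compounds alone, the (2-aminoethyl)amino group of compound 2 turns out not to be the only group on this carbonyl carbon that gives a measurable value: (1-carboxy-2-methylbutyl)amino brings an at least 14-fold lower number from compound 3 to compound 4 (1.16 log units; beyond the scatter), and also an at least 14-fold lower number from compound 1 to compound 4 (1.16 log units; beyond the scatter). Compound 2 still keeps an edge, with a 3.4-fold higher number from compound 2 to compound 4 (0.53 log units; beyond the scatter), so a carboxylic acid-bearing chain comes close to the amine-bearing one without matching it. The two large steps are floors rather than full sizes, as each starts from a limit: the limit of > 50000 nM in this assay, at which 2 of the 4 values shown sit.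

On these data alone, it remains open whether the step goes with the carboxylic acid, with the branched chain or with the two defined stereocentres of 1-carboxy-2-methylbutyl. Also open, as far as these compounds go, is how a plain carboxymethyl group or a longer amine such as 3-aminopropyl would behave on the same amide-type nitrogen.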